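Compound 3: phenyl in place of methyl, expected read-out

The compounds below may be only part of what the source reports. "The series", "measured", "known", "first", "only" and "open" are said of these compounds alone.

For the measured compounds named here, compound 1 `C=C1C(=O)O[C@@H](c2ccccc2)[C@H]1C` gives in a functional assay on BXPC-3 cells (Homo sapiens) for cytotoxicity, read by MTT assay, with a stated time of 72 h, tested at 1 uM (a lower number here means a stronger effect, a higher number a weaker effect of the compound at the concentration tested), a read-out of 98%, which is the lowest of the two numbers measured so far; the nearest is compound 2 `C=C1C(=O)O[C@@H](c2ccc(OC)cc2)[C@H]1C`, which gives 128% in this assay. Going by the values given here, the only measured step is a number 30 percentage points higher from compound 1 to compound 2 (beyond the scatter). Compound 3 `C=C1C(=O)O[C@@H](c2ccccc2)[C@H]1c1ccccc1` differs from compound 1 by phenyl in place of methyl on a saturated ring carbon. Among the compounds with values here, that step with methoxy concerns an aromatic carbon, not a saturated ring carbon of the five-membered non-aromatic ring with one oxygen, so it does not bear on the change to compound 3, and no other measured pair speaks to a phenyl entering there. With nothing to anchor a direction, the expected step in this assay is none beyond the scatter, though with a wide allowance: a number 3 percentage points lower from compound 1 to compound 3 (within the scatter) is the estimate. For compound 3 the value expected in this assay is 95%, between 65% and 125%.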

Compound 3, a percentage reported as activity, at one concentration (the size of the read-out at that concentration, not a potency): 51%
For compound 3 the middle estimate is 44 percentage points above the measured one; the measured number lies below the stated range.
By their numbers in this assay, from the lowest: compound 3; then compound 1; then compound 2.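

The saturated ring carbon two ring bonds from the ring oxygen responds strongly in this assay: phenyl in place of methyl there gives a number 47 percentage points lower from compound 1 to compound 3 (beyond the scatter). For the compounds shown here, this is the first step towards a stronger effect at the concentration tested, whereas the earlier step, a number 30 percentage points higher from compound 1 to compound 2 (beyond the scatter), went towards a weaker effect and concerned an aromatic carbon. The data at hand offer no explanation for the size or direction of the new step.

As far as these compounds go, it remains open whether the effect requires an aromatic ring at this carbon, or whether a cyclohexyl group or a longer chain such as n-butyl would also lower the number. Also open, from the compounds shown here alone, is how methoxy, an amine or a carboxylic acid on the entering phenyl would change the read-out.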